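The source may hold more compounds than are shown below. What is called first, only, known or untested is meant among the compounds shown, and "the series" means these compounds.

Compound 1 `C/C=C(\C)[C@@H](O)[C@H](C)[C@H](O)C/C=C(C)/C=C(\C)C/C(C)=C/C/C=C(\C)[C@@H](O)[C@@H](C)[C@H]1CC[C@H](CCCC)C(=O)O1` gives 32000 nM
Compound 2 `C/C=C(\C)[C@@H](O)[C@H](C)[C@H](O)C/C=C(C)/C=C(\C)C/C(C)=C/C/C=C(\C)[C@@H](O)[C@@H](C)[C@H]1CC[C@H](CCC)C(=O)O1` gives 31000 nM

Both values come from a toxicity assay on 3Y1 cells for inhibition, with 3Y1 cell line (Rattus norvegicus) as the target, read by MTT assay, with a stated time of 84 h; a higher number here means a weaker inhibitor of growth, a lower number a stronger inhibitor of growth. Only these two numbers exist so far, and they lie within the scatter of each other, so compound 2 stands level with compound 1.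

Compound 3 `C/C=C(\C)[C@@H](O)[C@H](C)[C@H](O)C/C=C(C)/C=C(\C)C/C(C)=C/C/C=C(\C)[C@@H](O)[C@@H](C)[C@H]1CC[C@H](CC)C(=O)O1` takes the chain on compound 2 from propyl to ethyl: hydrogen in place of methyl on a saturated chain carbon, two bonds along the chain from a saturated ring carbon. In other words, hydrogen replaces methyl on a saturated chain carbon, two bonds along the chain from a saturated ring carbon.

For the measured compounds named here, one measured step bears on this, the same swap made three bonds along the chain: a 1.0-fold lower number from compound 1 to compound 2 (0.01 log units; within the scatter). That single step is thin evidence, and the new place is untested, but it gives no reason to expect a real shift in either direction in this assay.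

The expected step is no change at the digits printed from compound 2 to compound 3 (within the scatter), which means no change beyond the scatter. For compound 3 the estimated value is 31000 nM, within an expected range of 17000 nM to 55000 nM.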

Compound 3, concentration for 50% growth inhibition: 3800 nM
Estimate against measurement, compound 3: 8.2-fold (0.91 log units) above; the measured number lies below the stated range.
By their numbers in this assay, from the lowest: compound 3; then compounds 2 and 1 (each within the scatter of the next).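

Within this assay, shortening this chain does not act evenly: the change from propyl to ethyl gives a clear shift (an 8.2-fold lower number from compound 2 to compound 3 (0.91 log units; beyond the scatter)), whereas the same swap of hydrogen for methyl one bond further out gave none beyond the scatter (a 1.0-fold lower number from compound 1 to compound 2 (0.01 log units; within the scatter)). The longer chain of compound 1 gives almost the same gap to the ethyl chain (an 8.4-fold lower number from compound 1 to compound 3 (0.93 log units; beyond the scatter)), so across these three compounds the number falls only once the chain reaches ethyl, while compounds 1 and 2 stand level. No separate measurement is available to account for this sharp change at ethyl.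

On these data alone, whether a still shorter methyl group at this place would lower the number further, hold it, or reverse the shift remains open. So does the effect of an amine or a hydroxyl group carried on the ethyl chain.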